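One Substituent Swap, Seen Twice Across Two Related Cores

The source may report more compounds than this note shows. Statements on the series, on what has been measured and on what is new or still open speak of the compounds shown alone.

Compound 1 `O=C(O)COc1ccc(/C=C/C(=O)c2ccc(Cl)c(Cl)c2)cc1`: 15000 nM
Compound 2 `O=C(/C=C/c1ccc(B(O)O)cc1)c1ccc(Cl)c(Cl)c1`: 5500 nM
Compound 3 `O=C(O)COc1ccc(C(=O)/C=C/c2ccc(Cl)c(Cl)c2)cc1`: 13000 nM

All three numbers come from a functional assay on MCF7 cells (Homo sapiens) for inhibition; a lower number here means a stronger inhibitor, a higher number a weaker inhibitor. Compound 1 and compound 2 share one core and differ in a single place: a group of 3 heavy atoms (1 boron, 2 oxygen; no ring) in place of a group of 5 heavy atoms (2 carbon, 3 oxygen; no ring), on an aromatic carbon. That swap produced a 2.7-fold lower number from compound 1 to compound 2 (0.44 log units; beyond the scatter).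

Compound 3 is built from the same atoms as compound 1, joined differently; the difference between the two cores is not broken down here. In this assay compound 3 gives 13000 nM, a number within the scatter of what compound 1 gives.

Compound 4 `O=C(/C=C/c1ccc(Cl)c(Cl)c1)c1ccc(B(O)O)cc1` has not yet been measured. It stands to compound 3 as compound 2 stands to compound 1: a group of 3 heavy atoms (1 boron, 2 oxygen; no ring) in place of a group of 5 heavy atoms (2 carbon, 3 oxygen; no ring), on an aromatic carbon. The place of the change is described in the same words for both pairs, so this is the same change made on a second core.

Within the data shown here, only one earlier example of the swap exists, so the expectation rests on it alone. Compound 4 is therefore expected to take a 2.6-fold lower number from compound 3 to compound 4 (0.41 log units; beyond the scatter). Compound 4 is estimated at 5000 nM, within an expected range from 2000 nM to 12000 nM. The range is kept wide because a 2.7-fold lower number from compound 1 to compound 2 (0.44 log units; beyond the scatter) is a single observation, and the two cores differ in a way that is not broken down here.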

Compound 4, half-maximal inhibitory concentration: 5000 nM
For compound 4 middle estimate and measured number coincide at the digits printed; the measured number falls inside the stated range.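

In this assay, putting the boron-bearing group in place of carboxymethoxy on the aromatic carbon of the second core gives a 2.6-fold lower number from compound 3 to compound 4 (0.41 log units; beyond the scatter). This is a modest step, but it is beyond the scatter, and it matches the step seen for the same swap on the first core, so within this small set the change carries from one core to the other with its size intact: the same change on two cores in this assay, a 2.7-fold lower number (0.44 log units; beyond the scatter) from compound 1 to compound 2 and a 2.6-fold lower number (0.41 log units; beyond the scatter) from compound 3 to compound 4, 1.0-fold (0.02 log units) apart, within the scatter of two such steps. Two pairs are still a small sample, so they do not show that the swap would act the same way on any further core, and they do not tell whether the lower number comes from gaining the boron-bearing group, from losing carboxymethoxy, or from both.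

The compounds shown leave open what other groups would do at this same place, such as an amine, a nitrile or a longer chain carrying the boron-bearing group at its end. As far as these compounds go, all four compounds also keep the same two chlorine atoms on the other ring, so it remains open whether the swap would give a similar step with fluorine or a methoxy group on that ring instead.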